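Bromine Enters the Benzyl Ring of Compound 3

The source may report more compounds than this note shows. Statements on the series, on what has been measured and on what is new or still open speak of the compounds shown alone.

Compound 3 `O=C(/C=C/c1ccc(OCc2cn(Cc3ccccc3)nn2)cc1)c1ccc(Br)cc1` gives 34% in a functional assay on A549 cells (Homo sapiens) for inhibition, read by MTT assay, with a stated time of 48 h, tested at 10 uM; a lower number here means less inhibition of growth, a higher number more inhibition of growth at the concentration tested. It carries the highest number of the three measured compounds, yet the gaps are small: compound 2 `C#CCOc1ccc(/C=C/C(=O)c2ccc([N+](=O)[O-])cc2)cc1` gives 33% in this assay, and compound 1 `C#CCOc1ccc(/C=C/C(=O)c2ccc(OC)cc2)cc1` gives 27% in this assay, both within the scatter of compound 3. Among the compounds with values here, the one measured step, a number 6 percentage points higher from compound 1 to compound 2 (within the scatter), was within the scatter as well.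

Compound 4 `O=C(/C=C/c1ccc(OCc2cn(Cc3ccccc3Br)nn2)cc1)c1ccc(Br)cc1` differs from compound 3 by bromo in place of hydrogen on an aromatic carbon. The bromo sits on an aromatic carbon of a six-membered aromatic ring of carbon only, ortho to a large group, so the benzyl becomes 2-bromobenzyl. Within the data shown here, no measured step follows a bromo entering this part of the shared core; the single measured step touches another ring and was itself within the scatter. Compound 4 is therefore expected to show no step beyond the scatter, no change at the digits printed from compound 3 to compound 4 (within the scatter). Compound 4 is estimated to give 34%, with a range from 20% to 48%.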

Compound 4, percent growth inhibition at one concentration: 44%
Compound 4: the middle estimate sits 10 percentage points below what was measured, within the range that was stated.
By their numbers in this assay, from the lowest: compounds 1, 2, 3 and 4 (each within the scatter of the next, the first and the last beyond it).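

In this assay, within the data shown here, the change to 2-bromobenzyl gives the first measured step on the benzyl ring of the shared core, a number 10 percentage points higher from compound 3 to compound 4 (within the scatter), and the earlier step touched only another ring. A bromo on an aromatic carbon of this ring, ortho to a large group, is thus accepted without a step beyond the scatter, so this place can carry the added heavy atom with growth inhibition still measurable at the concentration tested. Nothing at hand explains the size of this step or says what the bromo does at this place.

As far as these compounds go, whether an amine, a methoxy or a carboxylic acid on the same aromatic carbon would give a step beyond the scatter stays open. The compounds shown also leave open what the bromo on the other ring of compound 3 contributes.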